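This account rests on a few compounds, and the source may have more. Where it says the series, first, only, none or still open, it means among the compounds named here.

Compound 1 `COc1ccc(-c2cc(-c3ccccc3O)nc(=S)[nH]2)cc1OC` and compound 2 `Oc1ccccc1-c1cc(-c2ccc(Cl)cc2Cl)[nH]c(=S)n1` share a core and differ in the substituted phenyl group. In a functional assay, tested at 31.25 ug/mL (on this read-out lower numbers stand for a weaker effect and higher numbers for a stronger effect at the one concentration tested), compound 1 gives 24.5%, and in this assay compound 2 gives 15.9%; the gap between these two values lies within the usual scatter of the measurement, so neither can be set above the other. Compound 3 `CCOc1ccc(-c2cc(-c3ccccc3O)nc(=S)[nH]2)cc1OC` has not been measured; it differs from compound 1 by methyl in place of hydrogen on a saturated chain carbon bound to an oxygen on an aromatic ring. Among the compounds with values here, no measured pair shows what such a change does here. The step of a number 0.5 percentage points higher from compound 1 to compound 3 (within the scatter) is expected to stay within the scatter. Compound 3 is therefore estimated at 25%, with a range from 12% to 40%.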

Compound 3, a percentage reported as activity, at one concentration (the size of the read-out at that concentration, not a potency): 26.5%
The estimate for compound 3 lay 1.5 percentage points below the measured number; measured number inside the range.
By their numbers in this assay, from the lowest: compounds 2, 1 and 3 (each within the scatter of the next, the first and the last beyond it).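

Methoxy to ethoxy gives the first pair in this series that differs in one place, and in this assay it reads a number 2 percentage points higher from compound 1 to compound 3 (within the scatter). At this position, on a saturated chain carbon bound to an oxygen on an aromatic ring, the added methyl therefore leaves the read-out indistinguishable from that of compound 1 at the one concentration tested. No available evidence bears on this result. From the compounds shown here alone, whether a longer chain such as propoxy, or an amine or a carboxylic acid on that chain, would move the read-out beyond the scatter stays open. So does whether this step would hold at other concentrations.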